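Quinazoline sulfonamide series: amine side chain to pyridylmethyl

A few compounds are considered here, and "the series" means these few. Any claim that something is new, unique, unknown or untested is made for them only; others in the source may bear on it.

Of the compounds shown here, three of the shared core have been measured in a functional assay on A549 cells (Homo sapiens) for antiproliferative activity, read by sulforhodamine B assay, with a stated time of 72 h; a higher number here means a weaker inhibitor, a lower number a stronger inhibitor. Compound 1 `COc1ncc(-c2ccc3ncnc(NCCN(C)C)c3c2)cc1NS(=O)(=O)c1ccc(F)cc1` gives 2420 nM. Compound 2 `COc1ncc(-c2ccc3ncnc(NCCCN(C)C)c3c2)cc1NS(=O)(=O)c1ccc(F)cc1F` gives 2780 nM, and compound 3 `CCCCS(=O)(=O)Nc1cc(-c2ccc3ncnc(NCCCN(C)C)c3c2)cnc1OC` gives 3520 nM. Compound 2 stands second highest of the three, but its nearest and furthest neighbours are compound 1 and compound 3, and both gaps are within the scatter; the three numbers are not distinguished from one another. Among the measured compounds shown here, the single one-point step, a 1.3-fold higher number from compound 2 to compound 3 (0.10 log units; within the scatter), changes the sulfonyl substituent and is within the scatter.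

Compound 4 `COc1ncc(-c2ccc3ncnc(NCc4ccncc4)c3c2)cc1NS(=O)(=O)c1ccc(F)cc1F` is not yet measured. Relative to compound 2 it carries pyridin-4-yl in place of 2-(dimethylamino)ethyl on a saturated chain carbon bound to a nitrogen on an aromatic ring. For the measured compounds named here, no measured step touches this part of the molecule: the only step concerns the sulfonyl sulfur, and compound 1 differs from compound 2 in two places at once, so its value is not a guide to this change alone. With nothing bearing on the chain position, the expectation for compound 4 rests on the narrow spread of the series, and the step of a 1.1-fold higher number from compound 2 to compound 4 (0.03 log units; within the scatter) is expected to be small, with no direction favoured. Compound 4 is therefore estimated at 3000 nM, in a range from 800 nM to 12000 nM.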

Compound 4, half-maximal inhibitory concentration: 11400 nM
Compound 4: middle estimate off by 3.8-fold (0.58 log units), on the low side; the range from low to high includes it.
By their numbers in this assay, from the lowest: compounds 1, 2 and 3 (each within the scatter of the next); then compound 4.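

In this assay, the chain carbon bound to the nitrogen on the aromatic ring is a position where a single change registers beyond the scatter: a 4.1-fold higher number from compound 2 to compound 4 (0.61 log units; beyond the scatter), with pyridin-4-yl in place of 2-(dimethylamino)ethyl. The only earlier one-place step, at the sulfonyl sulfur, stayed within the scatter at a 1.3-fold higher number from compound 2 to compound 3 (0.10 log units; within the scatter), so the amine side chain is the part of the molecule shown to move this read-out, and this change moves it towards weaker inhibition. No measurement available here accounts for the step.

Among the compounds shown here, the one step replaces the 3-(dimethylamino)propyl chain with (pyridin-4-yl)methyl, so the effects of chain length and of the end group remain unseparated. From the compounds shown here alone, a benzyl group or a 3-(pyridin-4-yl)propyl chain at this position would help to separate them, and whether the step holds with a butyl group on the sulfonyl sulfur also remains open.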